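The source may hold more compounds than are shown below. What is called first, only, known or untested is meant among the compounds shown, and "the series" means these compounds.

Compound 1 `O=C(O)CS(=O)(=O)c1ccc(OCc2cccc(-c3ccccc3C(F)(F)F)c2)cc1`: 52.5 nM
Compound 2 `Cc1ccc(-c2cccc(COc3ccc(S(=O)(=O)CC(=O)O)cc3)c2)c(Cl)c1`: 36.3 nM

In a functional assay on CHO cells for agonist activity at Free fatty acid receptor 1 (Homo sapiens), read by FLIPR and calcium flux (on this read-out lower numbers stand for an effect already at smaller amounts and higher numbers for an effect only at larger amounts of compound), compound 2 gives 36.3 nM, the lowest of the two numbers recorded so far; compound 1 gives 52.5 nM, and the step of a 1.4-fold lower number from compound 1 to compound 2 (0.16 log units; within the scatter) lies within the scatter, so the two compounds cannot be told apart on this read-out. Compound 3 `Cc1ccc(C)n1-c1cccc(COc2ccc(S(=O)(=O)CC(=O)O)cc2)c1` has not yet been measured. It differs from compound 2 at one place: 2,5-dimethyl-1H-pyrrol-1-yl in place of 2-chloro-4-methylphenyl on an aromatic carbon. Going by the values given here, the one measured step at this place, a 1.4-fold lower number from compound 1 to compound 2 (0.16 log units; within the scatter), exchanged one substituted phenyl for another and left the number essentially unchanged. Among the compounds with values here, no measured step covers the exchange of a six-membered carbon ring for a five-membered ring with one hetero atom, so the expectation rests on that single step alone and is held loosely. The number expected for compound 3 is 80 nM, with a range from 25 nM to 300 nM, which would mean an estimated step of a 2.2-fold higher number from compound 2 to compound 3 (0.34 log units; beyond the scatter).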

Compound 3, half-maximal effective concentration: 129 nM
Estimate against measurement, compound 3: 1.6-fold (0.21 log units) below; low and high end bracket the measured number.
By their numbers in this assay, from the lowest: compounds 2 and 1 (each within the scatter of the next); then compound 3.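

In this assay, exchanging one substituted phenyl for another stayed within the scatter, but 2,5-dimethyl-1H-pyrrol-1-yl, a five-membered aromatic ring with 1 hetero atom, gives a 3.6-fold higher number from compound 2 to compound 3 (0.55 log units; beyond the scatter) and a 2.5-fold higher number from compound 1 to compound 3 (0.39 log units; beyond the scatter). This place, on an aromatic carbon and meta to a large group, therefore responds to the group it carries, and both steps beyond the scatter are modest in size. No measurement at hand explains this rise in the number.

The compounds shown change ring size, the nitrogen and the methyl groups all at once, so it stays open which of these accounts for the step. An unsubstituted pyrrol-1-yl or a pyridyl group at the same place would be needed to separate them.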